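Swapping the sulfonyl aryl group in a chromone series

The compounds below may be only part of what the source reports. "The series", "measured", "known", "first", "only" and "open" are said of these compounds alone.

Measured compounds:
Compound 1 `C=CCNC(=O)n1c(-c2ccc(OC)cc2)cc(=O)c2c(OC)cc(OC)cc21` in a functional assay on SUP-B15 cells (Homo sapiens) for antiproliferative activity, with a stated time of 72 h (a lower number here means that less compound is needed, a higher number that more compound is needed for the effect), gives 16000 nM.
Compound 2 `COc1ccc(-c2cc(=O)c3c(OC)cc(OC)cc3n2S(=O)(=O)c2cccc([N+](=O)[O-])c2)cc1` in this assay gives > 39600 nM, which is a limit of the assay, not a number.
Compound 3 `COc1ccc(-c2cc(=O)c3c(OC)cc(OC)cc3n2S(=O)(=O)c2ccc(Cl)cc2)cc1` in this assay gives > 34400 nM, also a limit of the assay rather than a number.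

Compound 3 therefore has no exact value; of the three results shown, two are limits (the limit of > 34400 nM in this assay, at which 1 of the 3 values shown sits, and (the limit of > 39600 nM in this assay, at which 1 of the 3 values shown sits)). The change from compound 1 gives an at least 2.1-fold higher number from compound 1 to compound 3 (0.33 log units; beyond the scatter), and the change from compound 2 gives a step that the two limits leave unreadable from compound 2 to compound 3.

Compound 4 `COc1ccc(-c2cc(=O)c3c(OC)cc(OC)cc3n2S(=O)(=O)c2ccc(Br)s2)cc1` differs from compound 3 by 5-bromothiophen-2-yl in place of 4-chlorophenyl on a sulfonyl sulfur. No measured step swaps one aromatic group for another on the sulfonyl sulfur, so neither step shown tells how large this change should be. With compound 3 at a limit and the sulfonyl series giving limits in this assay throughout, the expectation for compound 4 is a step that the limit leaves unreadable from compound 3 to compound 4, most likely again a limit. The estimated value for compound 4 is 40000 nM, within a range from 15000 nM to 100000 nM.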

Compound 4, half-maximal effective concentration: > 48200 nM
Compound 4 gave a limit, no number; the forecaster's own chance of this, stated with the estimate: 70%; middle value at least 1.2-fold (0.08 log units) from the limit.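

In this assay, compound 4 also gives only a limit of the assay: the limit of > 48200 nM in this assay, at which 1 of the 4 values shown sits. A five-membered aromatic ring carrying bromine on the sulfonyl sulfur therefore ends the same way as the 4-chlorophenyl of compound 3 and the 3-nitrophenyl of compound 2, each of which also gives a limit rather than a number. Replacing allylcarbamoyl on the aromatic nitrogen with (5-bromothiophen-2-yl)sulfonyl gives an at least 3.0-fold higher number from compound 1 to compound 4 (0.47 log units; beyond the scatter), while the steps among the three sulfonyl compounds cannot be read, since both ends of each are limits.

As far as these compounds go, how these three sulfonyl compounds rank against one another in this assay stays open. Also open, from the compounds shown here alone, is whether a plain methyl on the sulfonyl sulfur, or a longer chain such as hexylcarbamoyl on the aromatic nitrogen, would give a number near that of compound 1, 16000 nM.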